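This account rests on a few compounds, and the source may have more. Where it says the series, first, only, none or still open, it means among the compounds named here.

Compound 1 `CCCCNC1=CC(=O)C=C(C(C)(C)C)C1=O` and compound 2 `CCCCCCCCNC1=CC(=O)C=C(C(C)(C)C)C1=O` share one core, while compound 3 `CCCCNC1=CC(=O)C(C(C)(C)C)=CC1=O` and compound 4 `CCCCCCCCNC1=CC(=O)C(C(C)(C)C)=CC1=O` share another; the difference between the two cores is not broken down here. In a functional assay on NCI-H460 cells (Homo sapiens) for cytotoxicity, read by MTT assay, with a stated time of 72 h (on this read-out lower numbers stand for stronger inhibition and higher numbers for weaker inhibition), compound 1 gives 13000 nM. Compound 2 gives 21000 nM in this assay. Between them stands one change, (butyl in place of hydrogen on a saturated chain carbon, four bonds along the chain from an amine nitrogen), and its step is a 1.6-fold higher number from compound 1 to compound 2 (0.21 log units; within the scatter).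

Compound 3 gives 72000 nM in this assay, the highest number among the three measured compounds, lying beyond the scatter from both compound 1 and compound 2. Compound 4 has not yet been measured. Within the data shown here, it differs from compound 3 by butyl in place of hydrogen on a saturated chain carbon, four bonds along the chain from an amine nitrogen, which is the same change as the one from compound 1 to compound 2, at the same place.

Because the earlier instance of this change gave a 1.6-fold higher number from compound 1 to compound 2 (0.21 log units; within the scatter), a step that stays within the scatter, compound 4 is expected to sit close to compound 3, with a step of about a 1.4-fold higher number from compound 3 to compound 4 (0.14 log units; within the scatter). On that single precedent, compound 4 is estimated at 100000 nM in this assay, with the likely range running from 40000 nM to 250000 nM. This estimate rests on one pair only and on the high number for compound 3, so it carries real uncertainty, and there is a fair chance that the result for compound 4 is reported only as a limit rather than a number.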

Compound 4, half-maximal inhibitory concentration: 65000 nM
The estimate for compound 4 lay 1.5-fold (0.19 log units) above the measured number; measured number inside the range.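

In this assay, putting butyl in place of hydrogen on a saturated chain carbon, four bonds along the chain from an amine nitrogen, gives a 1.1-fold lower number from compound 3 to compound 4 (0.04 log units; within the scatter), so on the core of compound 3 this change leaves no reading beyond the usual scatter. Set beside its earlier instance on the core of compound 1, the step shows no detectable dependence on the core, and the change carries across the two cores without a difference that can be told from the scatter: the same change on two cores in this assay, a 1.6-fold higher number (0.21 log units; within the scatter) from compound 1 to compound 2 and a 1.1-fold lower number (0.04 log units; within the scatter) from compound 3 to compound 4, 1.8-fold (0.25 log units) apart, within the scatter of two such steps This does not show that the two cores respond identically, since a small real difference could lie hidden in the scatter, and with only two pairs, neither giving a step beyond the scatter, it says nothing of how the change would behave on any further core.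

The compounds shown leave open how a longer chain such as dodecyl, a chain ending in a hydroxyl group or an amine, or a phenyl ring in place of the chain would read on either core. They also leave open whether this agreement between the two cores would hold in cells other than those of this assay.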